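Shortening a carbamate chain on a selenocyanate aniline

The source may report more compounds than this note shows. Statements on the series, on what has been measured and on what is new or still open speak of the compounds shown alone.

Of the compounds shown here, three built around an aniline carbamate carrying selenium have been tested in a functional assay on HT-29 cells (Homo sapiens) for cytotoxicity, read by MTT assay, with a stated time of 72 h; on this read-out higher numbers stand for weaker inhibition of growth and lower numbers for stronger inhibition of growth. Compound 1 `CC(C)COC(=O)Nc1ccc([Se][Se]c2ccc(NC(=O)OCC(C)C)cc2)cc1` is a symmetric dimer linked through selenium, and in this assay compound 1 gives 48600 nM. Compound 2 `CCCCOC(=O)Nc1ccc([Se]C#N)cc1` carries a single selenocyanate group together with a butyl carbamate, and in this assay compound 2 gives 31300 nM. Compound 3 `N#C[Se]c1ccc(NC(=O)Oc2ccc(Cl)cc2)cc1` keeps the selenocyanate but has a chlorophenyl carbamate in place of the alkyl one, and compound 3 gives 40300 nM. Compound 2 has the lowest of the three numbers, yet its gap to compound 3 and its gap to compound 1 both sit within the scatter of repeat measurements, so the three cannot be ranked against one another.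

Compound 4 `CCOC(=O)Nc1ccc([Se]C#N)cc1` has not been measured. It differs from compound 2 in one place: hydrogen in place of ethyl on a saturated chain carbon, two bonds along the chain from an oxygen next to a carbonyl group. Among the measured compounds shown here, no measured pair shows what such a shortening of the chain does here, so there is no step to lean on. A shortening of the chain on the ester side of a carbamate is a modest change, and the expectation is a step from compound 2 to compound 4 of a 1.3-fold higher number from compound 2 to compound 4 (0.11 log units; within the scatter), most likely no larger than the scatter. Compound 4 is therefore estimated at 40000 nM, with a range from 15000 nM to 110000 nM.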

Compound 4, concentration for total growth inhibition: 38000 nM
Estimate against measurement, compound 4: 1.1-fold (0.02 log units) above; the range from low to high includes it.
By their numbers in this assay, from the lowest: compounds 2, 4, 3 and 1 (each within the scatter of the next).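

Among the compounds shown here, this is the first pair that differs in one place only, so the length of the carbamate chain can now be judged directly rather than through compounds that also differ elsewhere. In this assay the change from butoxy to ethoxy gives a 1.2-fold higher number from compound 2 to compound 4 (0.08 log units; within the scatter) and so shows no readable effect of removing these two carbon atoms, which suggests that growth inhibition at this place does not depend on the difference between these two chains. No outside measurement bears on this result, so the data offer no account of what lies behind it.

On these data alone, what a longer chain such as hexyl or octyl would do at this place stays open, as does the effect of a chain ending in an amine or a carboxylic acid, and a single pair of close chains cannot say how far this flat picture extends. Equally open, as far as these compounds go, is whether a thiocyanate in place of the selenocyanate on the core of compound 4 would shift the number by more than the usual scatter.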